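Replacing the 1H-benzimidazol-1-yl group of compound 3

A few compounds are considered here, and "the series" means these few. Any claim that something is new, unique, unknown or untested is made for them only; others in the source may bear on it.

Measured in an ADME assay on MCF7 cells (Homo sapiens) for inhibition; on this read-out higher numbers stand for weaker inhibition and lower numbers for stronger inhibition:
Compound 1 `COC(=O)c1cc2c(F)c(F)c(-n3cnc4ccccc43)c(F)c2s1`: > 12000 nM
Compound 2 `COC(=O)CSc1c(F)c(F)c2cc(C(=O)OC)sc2c1F`: > 25000 nM
Compound 3 `O=C(c1ccccc1)c1cc2c(F)c(F)c(-n3cnc4ccccc43)c(F)c2s1`: > 25000 nM

Compound 3 stands at > 25000 nM, which is only a limit, as are the other two entries. Compound 4 `O=C(c1ccccc1)c1cc2c(F)c(F)c(Sc3ccccc3Br)c(F)c2s1` differs from compound 3 at one place: (2-bromophenyl)sulfanyl in place of 1H-benzimidazol-1-yl on an aromatic carbon. For the measured compounds named here, the one measured step, a step that the two limits leave unreadable from compound 1 to compound 3, concerns another place and gives no size to carry over. Going by the values given here, compound 2 also bears a sulfanyl group and shows > 25000 nM, again a limit, so compound 4 is expected to read weakly in this assay too, with no direction of step foreseeable. For compound 4 the estimated value is 20000 nM, with an expected range of 6000 nM to 45000 nM.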

Compound 4, half-maximal inhibitory concentration: > 25000 nM
Compound 4 was reported as a limit (the forecaster's own chance of this, stated with the estimate: 65%); at least 1.2-fold (0.09 log units) between middle value and limit.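

For the compounds shown here, compound 3 and compound 4 are both reported only as limits, so no step between them can be read. The compounds shown leave open how strongly any of them inhibits in this assay, since none gives a measured number.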